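Swapping the amine side chain for a short amide

This account rests on a few compounds, and the source may have more. Where it says the series, first, only, none or still open, it means among the compounds named here.

In a functional assay on PC-3 cells (Homo sapiens) for antiproliferative activity, read by MTT assay, with a stated time of 48 h (a lower number here means a stronger inhibitor, a higher number a weaker inhibitor), the measured compounds give
Compound 1 `CCn1c(C(=O)NCCCN(C)C)ccc1C(CC)(CC)c1ccc(OCCC(O)(CC)CC)c(C)c1` at 2150 nM
Compound 2 `CCn1c(C(=O)NCCN(C)C)ccc1C(CC)(CC)c1ccc(OCCC(O)(CC)CC)c(C)c1` at 870 nM
Compound 3 `CCN(CC)CCNC(=O)c1ccc(C(CC)(CC)c2ccc(OCCC(O)(CC)CC)c(C)c2)n1CC` at 3350 nM

The data show a 1.6-fold higher number from compound 1 to compound 3 (0.19 log units; within the scatter) and so no order between those two. They also show a 3.9-fold higher number from compound 2 to compound 3 (0.59 log units; beyond the scatter) and this makes compound 3 the weaker of that pair. Compound 4 `C=CCN(C)C(=O)c1ccc(C(CC)(CC)c2ccc(OCCC(O)(CC)CC)c(C)c2)n1CC` has allyl(methyl)amino in place of (2-(diethylamino)ethyl)amino on a carbonyl carbon. The closest evidence is a 2.5-fold lower number from compound 1 to compound 2 (0.39 log units; beyond the scatter) and a 3.9-fold higher number from compound 2 to compound 3 (0.59 log units; beyond the scatter). Among the compounds with values here, both only alter the amine end, and no measured compound lacks it, so direction stays uncertain. The expected change is a 1.1-fold lower number from compound 3 to compound 4 (0.05 log units; within the scatter) and thus none beyond the scatter in this assay is foreseen. Compound 4 is estimated at 3000 nM within an expected range of 800 nM to 11000 nM as a cautious guess.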

Compound 4, half-maximal inhibitory concentration: 12800 nM
Compound 4: the middle estimate sits 4.3-fold (0.63 log units) below what was measured, outside the stated range (above it).
By their numbers in this assay, from the lowest: compound 2; then compounds 1 and 3 (each within the scatter of the next); then compound 4.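

Against every earlier compound, allyl(methyl)amino on the carbonyl carbon gives a weaker result in this assay: a 3.8-fold higher number from compound 3 to compound 4 (0.58 log units; beyond the scatter) and a 6.0-fold higher number from compound 1 to compound 4 (0.77 log units; beyond the scatter) and a 15-fold higher number from compound 2 to compound 4 (1.17 log units; beyond the scatter). Within the data shown here, the earlier compounds differed only within an aminoalkyl chain, whereas replacing that whole group gives the one large step here, so this position does respond to its substituent. Nothing measured here explains the loss.

The swap removes the amide hydrogen and the chain's amine end together, so their separate contributions stay unresolved. As far as these compounds go, whether methylamino or piperidine on the carbonyl carbon would lie closer to compound 2 or compound 4 remains open.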